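Swapping a phenyl for a methyl on the indole core

The compounds below may be only part of what the source reports. "The series", "measured", "known", "first", "only" and "open" are said of these compounds alone.

Of the compounds shown here, three have been tested in an assay on isolated protein for displacement of a labelled ligand from prostaglandin D2 receptor 2 (Homo sapiens); a higher number here means a weaker inhibitor, a lower number a stronger inhibitor. Compound 1 `Cc1c(Sc2ccc(Cl)cc2)c2cc(-c3ccccc3)ccc2n1CC(=O)O` gives 3.5 nM, the lowest of the three numbers. Compound 3 `CC(=O)Nc1cccc2c1c(S(=O)(=O)c1ccc(Cl)cc1)c(C)n2CC(=O)O` gives 7.1 nM, a somewhat higher number than compound 1, beyond the usual scatter. Compound 2 `Cn1c(CC(=O)O)c(Sc2ccccc2)c2ccccc21` gives 794 nM, far higher than both. Compound 4 `Cc1ccc2c(c1)c(Sc1ccc(Cl)cc1)c(C)n2CC(=O)O` has not yet been measured in this assay. It differs from compound 1 in one place: methyl in place of phenyl on an aromatic carbon. Among the measured compounds shown here, no measured pair shows this exact change, so the step can only be guessed. The much higher number of compound 2, which carries no group at all at this position, suggests the phenyl matters, and a weaker result is expected for compound 4, with a step of a 7.1-fold higher number from compound 1 to compound 4 (0.85 log units; beyond the scatter) beyond the scatter. Compound 4 is thus estimated at 25 nM, most likely between 6 nM and 100 nM.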

Compound 4, half-maximal inhibitory concentration: 15 nM
Beside the measured number, compound 4's estimate is 1.7-fold (0.22 log units) above it; low and high end bracket the measured number.
By their numbers in this assay, from the lowest: compound 1; then compound 3; then compound 4; then compound 2.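

Among the compounds shown here, putting methyl in place of phenyl gives a 4.3-fold higher number from compound 1 to compound 4 (0.63 log units; beyond the scatter), the first direct reading of this change. The phenyl therefore helps, yet the step is modest: a ring of six carbons can give way to a single carbon with only this loss. Nothing at hand explains the size of the step.

On these data alone, how an ethyl chain, an amine or a carboxylic acid on this aromatic carbon would compare stays open. So does whether the same change gives a similar step with a different group on the sulfur.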